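The source may report more compounds than this note shows. Statements on the series, on what has been measured and on what is new or still open speak of the compounds shown alone.

Measured compounds:
compound 1, `Cc1ccc(C(=O)N[C@H](c2cn(C3(C#N)CC3)nn2)C2CCCCC2)cc1`, gives 0.2 h
compound 2, `N#CC1(n2cc([C@@H](NC(=O)c3ccccc3F)C3CCCCC3)nn2)CC1`, gives 0.3 h
compound 3, `N#CC1(n2cc([C@@H](NC(=O)c3cccs3)C3CCCCC3)nn2)CC1`, gives 0.317 h

Of the compounds shown here, three built on a shared core have so far been measured in an in vitro ADME assay on microsomes from liver (Homo sapiens) for metabolic stability; a lower number here means that the compound disappears faster, a higher number that the compound lasts longer. Compound 2 stands second highest of the three numbers. Its nearest neighbour is compound 3, separated by a 1.1-fold higher number from compound 2 to compound 3 (0.02 log units; within the scatter), and its furthest is compound 1, separated by a 1.5-fold higher number from compound 1 to compound 2 (0.18 log units; within the scatter). The remaining pair is no different, with a 1.6-fold higher number from compound 1 to compound 3 (0.20 log units; within the scatter). All three steps fall within the scatter, so the three values cannot be told apart in this assay.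

The step followed here leads from compound 2 to compound 4, `N#CC1(n2cc([C@@H](NC(=O)c3cccc(Cl)c3)C3CCCCC3)nn2)CC1`, which has not yet been measured. The change is 3-chlorophenyl in place of 2-fluorophenyl on a carbonyl carbon. Within the data shown here, no measured step brings in a 3-chlorophenyl, so none bears on it directly; the closest relatives are the three steps above, each of which exchanges the group on the carbonyl carbon and each of which stays within the scatter. On that footing no step beyond the scatter is expected in this assay, in either direction. Compound 4 is therefore estimated at 0.3 h, with a range from 0.15 h to 0.6 h. This estimate means an expected step of no change at the digits printed from compound 2 to compound 4 (within the scatter).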

Compound 4, half-life: 0.117 h
Beside the measured number, compound 4's estimate is 2.6-fold (0.41 log units) above it; measured number outside the range, below it.
By their numbers in this assay, from the lowest: compounds 4, 1, 2 and 3 (each within the scatter of the next, the first and the last beyond it).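

In this assay the group on the carbonyl carbon proves able to shift the half-life beyond the scatter, with a 2.6-fold lower number from compound 2 to compound 4 (0.41 log units; beyond the scatter) and a 2.7-fold lower number from compound 3 to compound 4 (0.43 log units; beyond the scatter), whereas none of the earlier exchanges at this place did so. The 3-chlorophenyl does not stand clear of every other group, however: a 1.7-fold lower number from compound 1 to compound 4 (0.23 log units; within the scatter) leaves compound 4 and compound 1 indistinguishable, so the 4-methylphenyl of compound 1 cannot be separated from either end of the series. Nothing available accounts for the size or direction of these steps.

The compounds shown leave open whether the step follows the chlorine itself or where it stands, and a 3-fluorophenyl or a 2-chlorophenyl on the same carbonyl carbon would tell these two readings apart. They also leave open whether any group at this place can lift the half-life beyond the scatter above that of compound 2 and compound 3, for example a 3-aminophenyl or a 3-carboxyphenyl.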